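The source may hold more compounds than are shown below. What is called first, only, known or untested is meant among the compounds shown, and "the series" means these compounds.

Measured so far:
- Compound 1 `C#CCSc1nc(NCCC(C)C)c2ccncc2n1`: > 80000 nM (a limit)
- Compound 2 `C#CCSc1nc(Nc2ccc(C)cc2)c2ccncc2n1`: 15700 nM

In a functional assay on PC-3 cells (Homo sapiens) for inhibition, read by MTT assay, with a stated time of 72 h (on this read-out higher numbers stand for weaker inhibition and lower numbers for stronger inhibition), compound 1 gives only a limit, > 80000 nM. Compound 3 `C#CCSc1nc(Nc2ccc(F)cc2)c2ccncc2n1` differs from it by 4-fluorophenyl in place of isopentyl on a nitrogen on an aromatic ring, with 4-fluorophenyl in place of isopentyl on a nitrogen on an aromatic ring. Among the compounds with values here, one measured step bears on this change: an at least 5.0-fold lower number from compound 1 to compound 2 (0.70 log units; beyond the scatter). It also replaces isopentyl with a six-membered aromatic ring at that place, so a step of similar size towards a lower number is expected in this assay. The expected step is an at least 4.4-fold lower number from compound 1 to compound 3 (0.64 log units; beyond the scatter). Compound 3 is estimated at 18000 nM, within a range of 6000 nM to 50000 nM.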

Compound 3, half-maximal inhibitory concentration: 17300 nM
Estimate against measurement, compound 3: 1.0-fold (0.02 log units) above; low and high end bracket the measured number.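

In this assay, the drop seen with 4-methylphenyl recurs with 4-fluorophenyl on the same nitrogen, with an at least 4.6-fold lower number from compound 1 to compound 3 (0.66 log units; beyond the scatter). The two aromatic groups are not told apart: fluoro in place of methyl on an aromatic carbon gives a 1.1-fold higher number from compound 2 to compound 3 (0.04 log units; within the scatter). The value of compound 1 is a limit, and the true size of the step from it stays unknown because of that: the limit of > 80000 nM in this assay, at which 1 of the 3 values shown sits.

Going by these compounds, whether a methoxy group or a carboxylic acid on that phenyl ring would separate from methyl and fluoro stays open. So does whether a benzyl group on the nitrogen would keep the lower number.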